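Trimming One Fluorine from the Sulfonyl Ring

The source may report more compounds than this note shows. Statements on the series, on what has been measured and on what is new or still open speak of the compounds shown alone.

Measured compounds:
compound 1 `O=C(NO)c1ccc(CN(Cc2ccccc2)S(=O)(=O)c2c(F)c(F)c(F)c(F)c2F)cc1` gives 122 nM
compound 2 `O=C(NO)c1ccc(CN(Cc2ccc(C(F)(F)F)cc2)S(=O)(=O)c2c(F)c(F)c(F)c(F)c2F)cc1` gives > 1000 nM
compound 3 `O=C(NO)c1ccc(CN(Cc2ccncc2)S(=O)(=O)c2c(F)c(F)c(F)c(F)c2F)cc1` gives > 1000 nM

Within the data shown here, in an assay on isolated protein for inhibition of histone deacetylase 11 (Homo sapiens), read by mobility shift assay (a higher number here means a weaker inhibitor, a lower number a stronger inhibitor), compound 1 gives 122 nM, the only plain number among the three measured compounds. For compound 2 the assay reports only a limit, > 1000 nM. For compound 3 it likewise reports only a limit, > 1000 nM. Both sit at the limit of > 1000 nM in this assay, at which 2 of the 3 values shown sit. The two readable steps, an at least 8.1-fold higher number from compound 1 to compound 2 (0.91 log units; beyond the scatter) and an at least 8.1-fold higher number from compound 1 to compound 3 (0.91 log units; beyond the scatter), alter the group on the sulfonamide nitrogen and leave the sulfonyl ring untouched, so neither bears directly on compound 4 `O=C(NO)c1ccc(CN(Cc2ccccc2)S(=O)(=O)c2cc(F)c(F)c(F)c2F)cc1`, which differs from compound 1 by hydrogen in place of fluoro on an aromatic carbon. Among the measured compounds shown here, with no measured step on that ring, compound 4 is expected to shift only modestly, a 2.0-fold higher number from compound 1 to compound 4 (0.31 log units; beyond the scatter). Compound 4 is therefore estimated at 250 nM, ranging from 80 nM to 900 nM.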

Compound 4, half-maximal inhibitory concentration: 115 nM
Estimate against measurement, compound 4: 2.2-fold (0.34 log units) above, and the stated range covers the measured number.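

In this assay, the change from 2,3,4,5,6-pentafluorophenyl to 2,3,4,5-tetrafluorophenyl reads a 1.1-fold lower number from compound 1 to compound 4 (0.03 log units; within the scatter), so the two compounds cannot be told apart. Unlike the two changes on the sulfonamide nitrogen, this first change on the sulfonyl ring shows that this one fluoro is not needed to hold the reading at this level. Nothing shown here bears on why that is so.

On these data alone, whether chloro, methoxy or an amine would fare the same on this carbon stays open. So does the effect of replacing any of the remaining fluoro groups with hydrogen.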